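This account rests on a few compounds, and the source may have more. Where it says the series, first, only, none or still open, it means among the compounds named here.

Measured so far:
compound 1, `CCCc1nc(C)c2cnnc(O)n12`, 56800 nM
compound 2, `Oc1nncc2c(Br)nc(Cc3ccccc3)n12`, > 48000 nM

Both were tested in a functional assay for inhibition, with Homo sapiens as the target; a higher number here means a weaker inhibitor, a lower number a stronger inhibitor. Compound 1 gives 56800 nM, a weak inhibition. For compound 2 this test reports only a limit, > 48000 nM, so no exact number is known for it. Compound 2 thus stands at the limit of > 48000 nM in this assay, at which 1 of the 2 values shown sits. The next compound, compound 3, has the structure `CCCc1nc(Br)c2cnnc(O)n12`. It differs from compound 2 in one place: ethyl in place of phenyl on a saturated chain carbon bound to an aromatic carbon. For the measured compounds named here, no two measured compounds differ from each other in a single place, so there is no measured guide to the size of such a change here; the only guide is that both measured compounds are weak. A step from compound 2 to compound 3 of a step that the limit leaves unreadable from compound 2 to compound 3 is expected, no larger than the usual scatter. Compound 3 is therefore expected to give about 55000 nM, in a range from 20000 nM to 150000 nM, and may well return as a limit only.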

Compound 3, half-maximal inhibitory concentration: > 48000 nM
Compound 3: only a limit was reported; the forecaster's own chance of this, stated with the estimate: 60%; the middle value is on the limit's open side.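

Like compound 2, compound 3 gives only a limit in this assay: the limit of > 48000 nM in this assay, at which 2 of the 3 values shown sit. As a result, no size can be read for the step to compound 3 from either compound 1 or compound 2. The compounds shown leave open whether either change, ethyl in place of phenyl or bromo in place of methyl, alters inhibition at all.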